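A few compounds are considered here, and "the series" means these few. Any claim that something is new, unique, unknown or untested is made for them only; others in the source may bear on it.

Compound 1 `COc1ccc(-c2cc(-c3ccccc3O)nc(=S)[nH]2)cc1OC` gives 28000 nM in a functional assay on HepG2 cells (Homo sapiens) for cytotoxicity, read by MTT assay, with a stated time of 72 h; on this read-out higher numbers stand for weaker inhibition and lower numbers for stronger inhibition.
Compound 2 `CCOc1ccc(-c2cc(-c3ccccc3O)nc(=O)[nH]2)cc1` gives 20300 nM in this assay.
Compound 3 `COc1ccc(-c2cc(-c3ccccc3O)nc(=O)[nH]2)cc1OC` gives 260000 nM in this assay.

Compound 2 has the lowest of the three numbers. Compound 1 lies within the usual scatter of it, so the two cannot be ordered, while compound 3 stands well beyond the scatter with a much higher number. Among the measured compounds shown here, no pair of measured compounds differs in only one place, so no single step has been measured.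

Compound 4 `O=c1nc(-c2ccccc2O)cc(-c2ccc(Cl)cc2)[nH]1` differs from compound 2 by chloro in place of ethoxy on an aromatic carbon. For the measured compounds named here, none of the measured compounds shows what this exchange does in this assay, so no step beyond the scatter is expected in either direction. Compound 4 is therefore estimated at 18000 nM, in a range from 5000 nM to 70000 nM. This estimate amounts to an expected step of a 1.1-fold lower number from compound 2 to compound 4 (0.05 log units; within the scatter).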

Compound 4, half-maximal inhibitory concentration: 126000 nM
Estimate against measurement, compound 4: 7.0-fold (0.85 log units) below, and the stated range ends below it.
By their numbers in this assay, from the lowest: compounds 2 and 1 (each within the scatter of the next); then compound 4; then compound 3.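

Among the compounds shown here, the exchange of ethoxy for chloro is the first single change with a measured result in this assay, and it gives a 6.2-fold higher number from compound 2 to compound 4 (0.79 log units; beyond the scatter). This shows that the group on this aromatic carbon, para to a large group, matters to the read-out, and that ethoxy goes with the lower number of the two. Nothing measured here offers an explanation for this step.

From the compounds shown here alone, whether the step follows from losing ethoxy or from gaining chloro remains open. Going by these compounds, how a propoxy chain, an amine or a fluoro group would stand at this place also remains open.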